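Enlarging the hydroxy side chain

A few compounds are considered here, and "the series" means these few. Any claim that something is new, unique, unknown or untested is made for them only; others in the source may bear on it.

In a functional assay on CH1 cells (Homo sapiens) for inhibition, read by sulforhodamine B assay, with a stated time of 96 h (on this read-out higher numbers stand for weaker inhibition of growth and lower numbers for stronger inhibition of growth), compound 1 `CC[C@@H](Nc1nc(NCc2ccccn2)c2ncn(C(C)C)c2n1)C(C)(C)O` is reported only as a limit of the assay, > 50000 nM. Compound 2 `CC[C@@H](Nc1nc(NCc2ccccn2)c2ncn(C(C)C)c2n1)C(C)O` gives 20000 nM, and compound 3 `CC[C@H](Nc1nc(NCc2ccccn2)c2ncn(C(C)C)c2n1)C(C)(C)O` gives 42000 nM, the higher of the two true numbers in this small set. Its nearest neighbour is compound 2, with a 2.1-fold higher number from compound 2 to compound 3 (0.32 log units; beyond the scatter).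

Compound 4 `CC[C@H](Nc1nc(NCc2ccccn2)c2ncn(C(C)C)c2n1)C(O)C(C)(C)C` differs from compound 3 in a single place: 1-hydroxy-2,2-dimethylpropyl in place of 1-hydroxy-1-methylethyl on a saturated chain carbon bound to a nitrogen on an aromatic ring and a saturated chain carbon. In words, 1-hydroxy-2,2-dimethylpropyl stands in place of 1-hydroxy-1-methylethyl.

Among the measured compounds shown here, three measured steps bear on this change. The clearest guide to chain size is an at least 2.5-fold lower number from compound 1 to compound 2 (0.39 log units; beyond the scatter), where hydrogen replaces methyl and the smaller chain goes with the lower number. The step of a 2.1-fold higher number from compound 2 to compound 3 (0.32 log units; beyond the scatter) points the same way, with the larger chain giving the higher number. The third, an at least 1.1-fold lower number from compound 1 to compound 3 (0.07 log units; that floor lies within the scatter), involves configuration alone and says little about chain size. These few compounds support no firm rule, but they give no reason to expect a lower number from a larger chain.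

Compound 4 may itself end at the limit of > 50000 nM in this assay, at which 1 of the 3 values shown sits. If a number is obtained, compound 4 is expected at about 40000 nM, within an estimated range of 20000 nM to 50000 nM. The expected change is a 1.1-fold lower number from compound 3 to compound 4 (0.02 log units; within the scatter), which would be no step beyond the scatter.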

Compound 4, concentration for 50% growth inhibition: > 50000 nM
Compound 4 gave a limit, no number (the forecaster's own chance of this, stated with the estimate: 40%); middle value at least 1.2-fold (0.09 log units) from the limit.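

In this assay compound 4 ends at a limit of the assay and gives no number, which puts this larger chain with compound 1 at the top of the range: the limit of > 50000 nM in this assay, at which 2 of the 4 values shown sit.

Putting 1-hydroxy-2,2-dimethylpropyl in place of 1-hydroxy-1-methylethyl on this saturated chain carbon gives an at least 1.1-fold higher number from compound 3 to compound 4 (0.07 log units; that floor lies within the scatter), so this change cannot be told apart from no change. The comparison with the smaller chain of compound 2 is clearer, with an at least 2.5-fold higher number from compound 2 to compound 4 (0.39 log units; beyond the scatter), and this adds a third readable step in which the larger chain goes with the higher number, alongside the steps from compound 1 to compound 2 and from compound 2 to compound 3; no compound shown goes against this, while the step from compound 1 to compound 4 cannot be read, since both are limits.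

On these data alone, the true numbers of compound 1 and compound 4 remain open, and so does the size of any step between compound 3 and compound 4. Also open, as far as these compounds go, is whether an amine or a carboxylic acid in place of the hydroxy group on this chain would give a lower number than compound 2.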